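The compounds below may be only part of what the source reports. "The series", "measured", "known", "first", "only" and "open" are said of these compounds alone.

Measured compounds in a functional assay on MCF7 cells (Homo sapiens) for cytotoxicity, read by sulforhodamine B assay, with a stated time of 48 h; a higher number here means a weaker inhibitor, a lower number a stronger inhibitor:

compound 1 `CC(=O)OC[C@H]1O[C@@H](n2cc(CN3C(=O)/C(=C\c4ccc(C)cc4)c4ccccc43)nn2)[C@H](OC(C)=O)[C@@H](OC(C)=O)[C@@H]1OC(C)=O` gives > 100000 nM
compound 2 `CC(=O)OC[C@H]1O[C@@H](n2cc(CN3C(=O)/C(=C\c4ccc(N(C)C)cc4)c4ccccc43)nn2)[C@H](OC(C)=O)[C@@H](OC(C)=O)[C@@H]1OC(C)=O` gives 29800 nM
compound 3 `CC(=O)OC[C@H]1O[C@@H](n2cc(CN3C(=O)/C(=C/c4ccc(N(C)C)cc4)c4ccccc43)nn2)[C@H](OC(C)=O)[C@@H](OC(C)=O)[C@@H]1OC(C)=O` gives 25200 nM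

The value given for compound 1 is a limit of this assay, not a number. Among the two numbers recorded, compound 2 has the higher one, and its nearest neighbour is compound 3, whose value sits within the scatter of it. The step from compound 1 to compound 2 was an at least 3.3-fold lower number from compound 1 to compound 2 (0.52 log units; beyond the scatter), brought about by dimethylamino in place of methyl on an aromatic carbon. The step from compound 2 to compound 3 was a 1.2-fold lower number from compound 2 to compound 3 (0.07 log units; within the scatter), the two differing only in the drawn configuration of the double bond.

Compound 4 `CC(=O)OC[C@H]1O[C@@H](n2cc(CN3C(=O)/C(=C\c4ccco4)c4ccccc43)nn2)[C@H](OC(C)=O)[C@@H](OC(C)=O)[C@@H]1OC(C)=O` is not yet measured. It differs from compound 2 by furan-2-yl in place of 4-(dimethylamino)phenyl on a double-bonded chain carbon bound to a double-bonded ring carbon. Among the measured compounds shown here, the step that bears on this change is the one from compound 1 to compound 2, where the loss of dimethylamino left compound 1 at a limit. Compound 4 likewise lacks dimethylamino, so a higher number in this assay is expected, of about a 2.7-fold higher number from compound 2 to compound 4 (0.43 log units; beyond the scatter). Compound 4 is therefore estimated at 80000 nM, with a range from 25000 nM to 300000 nM, and it may well return only a limit.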

Compound 4, half-maximal inhibitory concentration: 38200 nM
For compound 4 the middle estimate is 2.1-fold (0.32 log units) above the measured one; measured number inside the range.
By their numbers in this assay, from the lowest: compounds 3, 2 and 4 (each within the scatter of the next). At a limit, above all of these: compound 1.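

In this assay, the change on a double-bonded chain carbon bound to a double-bonded ring carbon shows that a measured number at this place does not depend on dimethylamino, since furan-2-yl in place of 4-(dimethylamino)phenyl gives a 1.3-fold higher number from compound 2 to compound 4 (0.11 log units; within the scatter). Furan-2-yl in place of 4-methylphenyl at the same place gives an at least 2.6-fold lower number from compound 1 to compound 4 (0.41 log units; beyond the scatter), so a step of at least modest size also occurs without dimethylamino, and the earlier step from the methyl compound can no longer be tied to that group alone. The full size of this step stays unknown because compound 1 stands at a limit: the limit of > 100000 nM in this assay, at which 1 of the 4 values shown sits.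

Among the compounds shown here, the only reading of the double-bond configuration comes from the 4-(dimethylamino)phenyl pair, a 1.2-fold lower number from compound 2 to compound 3 (0.07 log units; within the scatter), so it remains open whether the same holds with furan-2-yl at this place. From the compounds shown here alone, it also remains open how a thiophen-2-yl or an unsubstituted phenyl group would read here, and whether any group at this place would give a number well below those of compounds 2, 3 and 4.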